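The compounds below may be only part of what the source reports. "The series", "measured", "known", "first", "only" and "open" are said of these compounds alone.

Notes on the series. Two compounds have numbers in an assay on cell membranes for binding affinity to 2-oxoglutarate receptor 1 (Rattus norvegicus), read by radioligand binding; a higher number here means a weaker inhibitor, a lower number a stronger inhibitor. Compound 1 `CC(C)(C)NC(=O)[C@H]1O[C@@H](n2cnc3c(N)ncnc32)[C@H](O)[C@@H]1O` carries a tert-butyl group on its amide-type nitrogen and gives 6850 nM in this assay. Compound 2 `CC(=O)NCCCCCCCCNC(=O)[C@H]1OC(n2cnc3c(N)ncnc32)[C@H](O)[C@@H]1O` differs from compound 1 in more than one place. In this assay compound 2 gives 10 nM. Compound 1 therefore holds the highest of the two numbers, and the gap to compound 2 lies well beyond the scatter. Going by the values given here, no pair of measured compounds differs in a single place, so the effect of any one change on its own is not known.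

Compound 3 `C[C@H]1CC[C@@H](NC(=O)[C@H]2O[C@@H](n3cnc4c(N)ncnc43)[C@H](O)[C@@H]2O)CC1` is not yet measured. Its difference from compound 1 is 4-methylcyclohexyl in place of tert-butyl on an amide-type nitrogen. Among the compounds with values here, the entering group counts more heavy atoms and brings a ring; the only point of comparison is compound 2, where a longer substituent on the same nitrogen goes with the far lower number 10 nM. The step from compound 1 to compound 3 is expected to lower the number, a 4.6-fold lower number from compound 1 to compound 3 (0.66 log units; beyond the scatter), by a moderate amount rather than the full distance to compound 2. Compound 3 is estimated at 1500 nM, with a range from 250 nM to 8000 nM.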

Compound 3, inhibition constant: 55.6 nM
Estimate against measurement, compound 3: 27-fold (1.43 log units) above; measured number outside the range, below it.
By their numbers in this assay, from the lowest: compound 2; then compound 3; then compound 1.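

Going by these compounds alone, on an amide-type nitrogen, 4-methylcyclohexyl in place of tert-butyl gives a 120-fold lower number from compound 1 to compound 3 (2.09 log units; beyond the scatter) in this assay, the first step that can be read at a single place. The substituent on this nitrogen can therefore move the number by a large amount on its own while the rest of the structure stays the same, which the earlier pair could not show, as compound 2 differs from compound 1 in more than one place. The counts of hydrogen-bond donors and acceptors and the net charge do not differ between the two groups, so the step goes with more heavy atoms, a six-membered non-aromatic ring of carbon only and two defined stereocentres, and the data on hand offer no explanation for it.

The compounds shown leave open whether the ring, the methyl group or the added carbon count goes with the step, a question that an unsubstituted cyclohexyl group or an open heptyl chain on the same nitrogen would address. They also leave open how the other stereoisomer of the 4-methylcyclohexyl group, or an amine on the ring, would read in this assay at this position.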